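One Group Swapped, One Cell Toxicity Number Awaited

The compounds below may be only part of what the source reports. "The series", "measured", "known", "first", "only" and "open" are said of these compounds alone.

Among the compounds with values here, only two compounds have numbers so far in an ADME assay on MT4 cells (Homo sapiens) for cytotoxicity, read by MTT assay; on this read-out higher numbers stand for lower toxicity in this test and lower numbers for higher toxicity in this test. Compound 1 `Cc1ccc(C(=O)N(C(=S)OCCN2C(=O)c3ccccc3C2=O)c2ccc(C)cc2)cc1` gives 83000 nM, and compound 2 `Cc1ccc(N(C(=O)c2cccc(Cl)c2Cl)C(=S)OCCN2C(=O)c3ccccc3C2=O)cc1` gives 35000 nM, the lower of the two numbers, so compound 2 is the more toxic in this test.

Compound 3 `Cc1ccc(N(C(=O)c2ccc(Br)c(C)c2)C(=S)OCCN2C(=O)c3ccccc3C2=O)cc1` keeps the shared core and changes one group: 4-bromo-3-methylphenyl in place of 2,3-dichlorophenyl on a carbonyl carbon. Here 4-bromo-3-methylphenyl stands in place of 2,3-dichlorophenyl on a carbonyl carbon.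

Within the data shown here, compound 3 gives up the group that arrived in the one measured step at this place, so a 2.4-fold lower number from compound 1 to compound 2 (0.38 log units; beyond the scatter), modest in size, points to a rise no larger than that step. Among the measured compounds shown here, one step is thin evidence, and the entering group has no measurement yet.

The expected change is a 1.4-fold higher number from compound 2 to compound 3 (0.15 log units; within the scatter). For compound 3 the estimate is 50000 nM, with an expected range from 20000 nM to 110000 nM.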

Compound 3, half-maximal cytotoxic concentration: > 100000 nM
Compound 3: no number, only a limit; the forecaster's own chance of this, stated with the estimate: 10%; at least 2.0-fold (0.30 log units) between middle value and limit.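

In this assay compound 3 gives > 100000 nM, which is a limit of the assay and not a number. Even so, the swap on the carbonyl carbon gives an at least 2.8-fold higher number from compound 2 to compound 3 (0.45 log units; beyond the scatter), and together with a 2.4-fold lower number from compound 1 to compound 2 (0.38 log units; beyond the scatter) this leaves compound 2, with its 2,3-dichlorophenyl group, as the most toxic of the three in this test. The comparison of the two other groups is far less firm, since its floor gives only an at least 1.2-fold higher number from compound 1 to compound 3 (0.08 log units; that floor lies within the scatter), and the assay's ceiling limits what can be read: the limit of > 100000 nM in this assay, at which 1 of the 3 values shown sits.

Going by these compounds, the true value of compound 3 remains open, and so does the order of compound 1 and compound 3. Also open, on these data alone, is whether a phenyl ring carrying an amine or a carboxylic acid at this place would give a higher or lower number.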